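Swapping sec-butyl for butyl at the assay limit

The compounds below may be only part of what the source reports. "The series", "measured", "known", "first", "only" and "open" are said of these compounds alone.

Compound 1 (`CCC(C)NC(=C\C(=O)/C=C/c1ccc(O)c(OC)c1)/C=C/c1ccc(O)c(OC)c1`) carries a sec-butyl group on an amine nitrogen. In an ADME assay on EA.hy 926 cells (Homo sapiens) for inhibition, read by sulforhodamine B assay, with a stated time of 72 h (on this read-out higher numbers stand for weaker inhibition and lower numbers for stronger inhibition), compound 1 gives > 25000 nM and this is a limit of the assay, not a number. Compound 2 (`CC(C)CNC(=C\C(=O)/C=C/c1ccc(O)cc1)/C=C/c1ccc(O)cc1`) gives > 25000 nM and this too is a limit. Compound 3 (`COc1cc(/C=C/C(=O)/C=C(/C=C/c2ccc(OC(C)=O)c(OC)c2)NCC(C)C)ccc1OC(C)=O`) gives > 25000 nM and this is again a limit. Compound 1 therefore stands where every other measured compound stands (the limit of > 25000 nM in this assay, at which 3 of the 3 values shown sit), with no exact value to compare.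

Compound 4 (`CCCCNC(=C\C(=O)/C=C/c1ccc(O)c(OC)c1)/C=C/c1ccc(O)c(OC)c1`) has the same atoms as compound 1, joined differently, with butyl in place of sec-butyl on an amine nitrogen. The shared core stays untouched.

Among the measured compounds shown here, no two measured compounds differ in just one place, so the data offer no measured step as a guide. The change only rearranges a chain of the same size, so no shift beyond the usual scatter is expected in this assay here. For compound 4 the expected step is small (a number no higher from compound 1 to compound 4 (the limit leaves the size open)). The estimate for compound 4 is 25000 nM within an expected range from 9000 nM to 60000 nM (and a reading that is again only a limit would be no surprise).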

Compound 4, half-maximal inhibitory concentration: > 25000 nM
Compound 4 was reported as a limit; the forecaster's own chance of this, stated with the estimate: 65%; the middle value sits exactly at the limit.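

In this assay compound 4 gives > 25000 nM, which is a limit of the assay and not a number. Among the compounds shown here, compound 1 also sits at a limit, so no step from compound 1 to compound 4 can be read. The compounds shown leave open whether butyl and sec-butyl differ at all, since none has an exact value: the limit of > 25000 nM in this assay, at which 4 of the 4 values shown sit.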